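A few compounds are considered here, and "the series" means these few. Any claim that something is new, unique, unknown or untested is made for them only; others in the source may bear on it.

Measured so far:
compound 1 `Cc1ccc(Nc2nc(SCc3cn(Cc4ccccc4Cl)nn3)nc(-c3ccc(C(C)C)cc3)c2C#N)cc1` gave 3530 nM
compound 2 `Cc1ccc(Nc2nc(SCc3cn(Cc4ccccc4Cl)nn3)nc(-c3ccc(C)cc3)c2C#N)cc1` gave 2630 nM

Both numbers come from a functional assay on B16-F10 cells (Mus musculus) for inhibition, read by MTT assay, with a stated time of 72 h; on this read-out higher numbers stand for weaker inhibition and lower numbers for stronger inhibition. Compound 2 holds the lower of the two numbers, and its nearest neighbour is compound 1, a gap that is within the scatter, so the two cannot be told apart. Within the data shown here, the single measured step is a 1.3-fold lower number from compound 1 to compound 2 (0.13 log units; within the scatter), where one small group on the same aromatic ring was swapped for another without a change beyond the scatter.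

Compound 3 `Cc1ccc(Nc2nc(SCc3cn(Cc4ccccc4Cl)nn3)nc(-c3ccc(Cl)cc3)c2C#N)cc1` differs from compound 2 by chloro in place of methyl on an aromatic carbon. Among the measured compounds shown here, no measured step swaps methyl for chloro, so the only guide is that the one swap already seen at this place left this assay unchanged within the scatter. The expectation is therefore no step beyond the scatter in this assay. Compound 3 is estimated at 2500 nM, with a range from 1000 nM to 6500 nM. The expected step is a 1.1-fold lower number from compound 2 to compound 3 (0.02 log units; within the scatter).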

Compound 3, half-maximal inhibitory concentration: 4810 nM
Compound 3: middle estimate off by 1.9-fold (0.28 log units), on the low side; measured number inside the range.
By their numbers in this assay, from the lowest: compounds 2, 1 and 3 (each within the scatter of the next).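

Swapping in chloro at this place on the ring gives a 1.8-fold higher number from compound 2 to compound 3 (0.26 log units; within the scatter) and, starting from isopropyl, a 1.4-fold higher number from compound 1 to compound 3 (0.13 log units; within the scatter) in this assay with both steps inside the scatter. Among these compounds, the earlier pair covered only two alkyl groups, whereas this position now also holds a halogen, and compounds 1, 2 and 3 still cannot be told apart. Nothing measured here explains why these three groups read alike, so the result stands as an observation only.

From the compounds shown here alone, it remains open whether a different kind of group at this place, such as an amine, a carboxylic acid or a methoxy group, would move the number beyond the scatter. Going by these compounds, it also remains open whether the same swap from 4-methylphenyl to 4-chlorophenyl would read the same with other groups elsewhere on the shared core.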